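The source may report more compounds than this note shows. Statements on the series, on what has been measured and on what is new or still open speak of the compounds shown alone.

Measured in a functional assay on PC-3 cells (Homo sapiens) for antiproliferative activity, read by MTT assay; on this read-out lower numbers stand for stronger inhibition and higher numbers for weaker inhibition:
Compound 1 `CCOC(=O)C1=C(C)OC(N)=C(C#N)C1c1ccc(OC2CCCC2)cc1`: 13300 nM
Compound 2 `CN1CCC(=O)/C(=C/c2ccc(OC3CCCC3)cc2)C1`: 10500 nM

Compound 2 and compound 1 give numbers that lie within the usual scatter of each other, so the two cannot be told apart on these data. Compound 3 `CCN1CCC(=O)/C(=C/c2ccc(OC3CCCC3)cc2)C1` has not yet been measured. It differs from compound 2 by methyl in place of hydrogen on a saturated chain carbon bound to an amine nitrogen in a ring. Among the measured compounds shown here, no measured pair shows what such a change does here, so no step beyond the scatter is expected in either direction. For compound 3 the estimated value is 10500 nM, with a range from 4000 nM to 26000 nM. The expected step of no change at the digits printed from compound 2 to compound 3 (within the scatter) is small.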

Compound 3, half-maximal inhibitory concentration: 9100 nM
Compound 3: middle estimate off by 1.2-fold (0.06 log units), on the high side, within the range that was stated.
By their numbers in this assay, from the lowest: compounds 3, 2 and 1 (each within the scatter of the next).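

In this assay, methyl in place of hydrogen on a saturated chain carbon bound to an amine nitrogen in a ring gives a 1.2-fold lower number from compound 2 to compound 3 (0.06 log units; within the scatter) and so leaves the two compounds indistinguishable. Among the compounds shown here, this pair, which the earlier compounds did not provide, shows that the change from methyl to ethyl at this place does not move the number beyond the scatter. Nothing measured here gives a reason for this result. Still open, on these data alone, is whether a longer chain such as propyl, or a benzyl group or a carboxylic acid, would separate from compound 2 and compound 3 at this place.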